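A few compounds are considered here, and "the series" means these few. Any claim that something is new, unique, unknown or untested is made for them only; others in the source may bear on it.

The set rests on a shared core carrying an arylsulfonyl group, and the compounds were tested in a functional assay on HCT-116 cells (Homo sapiens) for inhibition, read by MTT assay, with a stated time of 72 h; a higher number here means a weaker inhibitor, a lower number a stronger inhibitor. Compound 2 `CCOC(=O)c1oc2ccc(NS(=O)(=O)c3ccc(F)cc3)cc2c1C` gives 10500 nM in this assay. Compound 1 `CCOC(=O)c1oc2ccc(NS(=O)(=O)c3ccc(C(F)(F)F)cc3)cc2c1C` gives 5030 nM in this assay. The change between them is trifluoromethyl in place of fluoro on an aromatic carbon and it produced a 2.1-fold lower number from compound 2 to compound 1 (0.32 log units; beyond the scatter).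

Compound 3 `Cc1c(C(=O)O)oc2ccc(N(Cc3ccccc3)S(=O)(=O)c3ccc(F)cc3)cc12` has a different core, and the difference between its core and that of compound 2 is not broken down here. In this assay compound 3 reaches only the limit of > 40000 nM, which is a limit of the assay and not a number, and this is the point at which (the limit of > 40000 nM in this assay, at which 1 of the 3 values shown sits).

Compound 4 `Cc1c(C(=O)O)oc2ccc(N(Cc3ccccc3)S(=O)(=O)c3ccc(C(F)(F)F)cc3)cc12` has not yet been measured in this assay. It differs from compound 3 by trifluoromethyl in place of fluoro on an aromatic carbon, the same change that carried compound 2 to compound 1, made at the same place. On the strength of the modest step from compound 2 to compound 1, the step from compound 3 to compound 4 in this assay is expected to be of a similar size, about an at least 1.1-fold lower number from compound 3 to compound 4 (0.05 log units; that floor lies within the scatter), and this expectation rests only on that single earlier step. Because compound 3 sits at the limit of > 40000 nM, a step of that size would leave the value of compound 4 near or beyond the limit, so the estimate for compound 4 in this assay is 35000 nM, with a range expected from 15000 nM to 80000 nM, and a real chance that only a limit is reported.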

Compound 4, half-maximal inhibitory concentration: 4130 nM
Beside the measured number, compound 4's estimate is 8.5-fold (0.93 log units) above it; the whole stated range lies above it.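

In this assay, trifluoromethyl in place of fluoro on an aromatic carbon gave an at least 9.6-fold lower number from compound 3 to compound 4 (0.98 log units; beyond the scatter), so the change pointed the same way on both cores, but its size did not carry over from one core to the other: the same change on two cores in this assay, a 2.1-fold lower number (0.32 log units; beyond the scatter) from compound 2 to compound 1 and an at least 9.6-fold lower number (0.98 log units; beyond the scatter) from compound 3 to compound 4, at least 4.6-fold (0.66 log units) apart, beyond the scatter of two such steps. As far as these compounds go, the value of compound 3 is a limit and not a number, so the step from it is only a floor, and its true size remains unknown: the limit of > 40000 nM in this assay, at which 1 of the 4 values shown sits. These two pairs show that the direction of the change held on the two cores shown and that a step measured on one core did not give the size of the step on the other; they do not show which part of the difference between the cores goes with the larger step, and they give no rule for a third core.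

The compounds shown leave open whether a group such as a nitrile, a methoxy group or a chlorine atom in the same place on the ring would follow the same direction on both cores. They also leave open how the change would behave on a core carrying an amide or an amine, and whether a pair with a true number at both ends would narrow the size of the step.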